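Side-chain exchange on the shared core: compound 3

The source may report more compounds than this note shows. Statements on the series, on what has been measured and on what is new or still open speak of the compounds shown alone.

In a functional assay on A549 cells (Homo sapiens) for antiproliferative activity, read by MTT assay, with a stated time of 48 h (on this read-out higher numbers stand for weaker inhibition and lower numbers for stronger inhibition), compound 1 (`CC(C)=CCC[C@]1(C)/C=C/[C@@H](OC(=O)C=C(C)C)[C@](C)(O)/C=C/C(=O)/C(CN2CCN(C)CC2)=C\C1`) gives 940 nM and compound 2 (`CC(C)=CCC[C@]1(C)/C=C/[C@@H](OC(=O)C=C(C)C)[C@](C)(O)/C=C/C(=O)/C(Cn2cc(CO)nn2)=C\C1`) gives 3470 nM. Compound 2 thus holds the higher, weaker of the two numbers. Compound 3 (`CC(C)=CCC[C@]1(C)/C=C/[C@@H](OC(=O)C=C(C)C)[C@](C)(O)/C=C/C(=O)/C(C(=O)N(C(C)C)C(C)C)=C\C1`) carries diisopropylcarbamoyl in place of (4-(hydroxymethyl)-1H-1,2,3-triazol-1-yl)methyl on a double-bonded ring carbon. Among the compounds with values here, only one measured step bears on this change: a 3.7-fold higher number from compound 1 to compound 2 (0.57 log units; beyond the scatter), a modest step made at the same place on the core. It shows that the number responds to this substituent, but neither compound has a carbamoyl group, so its direction does not carry over. A shift beyond the scatter is therefore not expected with any confidence, with only a slight lean towards a lower number. The estimated change is a 1.4-fold lower number from compound 2 to compound 3 (0.16 log units; within the scatter). For compound 3 the expected value is 2400 nM, with an estimated range of 700 nM to 8000 nM.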

Compound 3, half-maximal inhibitory concentration: 13500 nM
The estimate for compound 3 lay 5.6-fold (0.75 log units) below the measured number; measured number outside the range, above it.
By their numbers in this assay, from the lowest: compound 1; then compound 2; then compound 3.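

In this assay, diisopropylcarbamoyl on the double-bonded ring carbon gives the highest number of the three compounds, with a 3.9-fold higher number from compound 2 to compound 3 (0.59 log units; beyond the scatter) and a 14-fold higher number from compound 1 to compound 3 (1.16 log units; beyond the scatter) as the two steps to it. The number at this position therefore spans a wider range than the single earlier step showed, and both side chains that carry a ring and are joined through a methylene give lower numbers than the ring-free carbamoyl group, with no compound shown going against this. No data at hand give a cause for this rise.

As far as these compounds go, whether the rise follows from the carbonyl bound directly to the ring carbon or from the two isopropyl groups remains open. A dimethylcarbamoyl group and a diisopropylaminomethyl group on the shared core would separate these two features.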